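The source may report more compounds than this note shows. Statements on the series, on what has been measured and on what is new or still open speak of the compounds shown alone.

For the measured compounds named here, only two compounds have numbers so far. In a functional assay on A-375 cells (Homo sapiens) for inhibition, read by MTT assay, with a stated time of 24 h (a lower number here means a stronger inhibitor, a higher number a weaker inhibitor), compound 1 `COc1cccc(N2CCN(c3c(CO)c(=O)oc4ccccc34)CC2)c1` gives 6510 nM and compound 2 `O=c1oc2ccccc2c(N2CCN(C(c3ccccc3)c3ccc(Cl)cc3)CC2)c1CO` gives 3890 nM. These two values lie within the usual scatter of repeated measurements, so compound 1 stands level with compound 2 and the pair cannot be ranked.

Compound 3 `COc1ccc(N2CCN(c3c(CO)c(=O)oc4ccccc34)CC2)cc1` has not yet been measured. It has the same atoms as compound 1, joined differently: 4-methoxyphenyl in place of 3-methoxyphenyl on an amine nitrogen in a ring. In words, 4-methoxyphenyl sits in place of 3-methoxyphenyl on an amine nitrogen in a ring, and the rest of the molecule stays the same.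

Going by the values given here, no measured pair shows what this kind of change does, so the data offer only indirect guidance. Compound 2, with a different group on that same nitrogen, gives 3890 nM, which is still within the scatter of compound 1. In this assay, a step no larger than the scatter is therefore expected, with neither direction favoured. The estimated step is a 1.2-fold lower number from compound 1 to compound 3 (0.07 log units; within the scatter). For compound 3 the estimated value is 5500 nM, with an expected range from 2500 nM to 12000 nM.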

Compound 3, half-maximal inhibitory concentration: 7230 nM
For compound 3 the middle estimate is 1.3-fold (0.12 log units) below the measured one; the range from low to high includes it.
By their numbers in this assay, from the lowest: compounds 2, 1 and 3 (each within the scatter of the next).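

For the compounds shown here, this is the first measured pair in which a single change can be read on its own: in this assay, putting 4-methoxyphenyl in place of 3-methoxyphenyl on an amine nitrogen in a ring gives a 1.1-fold higher number from compound 1 to compound 3 (0.05 log units; within the scatter). The two groups have the same atoms and the same counts of heavy atoms and hydrogen-bond acceptors, and in this assay compound 1 and compound 3 cannot be told apart, so shifting the methoxy group around this aromatic ring, at least between these two arrangements, has no effect that this read-out can resolve. No separate measurement bears on this result, and why the two compounds read alike remains unknown.

What the compounds shown leave open is whether this insensitivity extends to other groups on the aromatic ring, such as a hydroxyl, an amine or a carboxylic acid in place of the methoxy group. Going by these compounds, it is also open whether a benzyl group or a longer chain on that same ring nitrogen would give a step larger than the scatter.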